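From propylamino to aminomethyl on a shared core

A few compounds are considered here, and "the series" means these few. Any claim that something is new, unique, unknown or untested is made for them only; others in the source may bear on it.

compound 1 `C=CCNc1ccc(/C=N/N=C(/N)S)nc1`: 4400 nM
compound 2 `CCCNc1ccc(/C=N/N=C(/N)S)nc1`: 5100 nM

Among the measured compounds shown here, both numbers come from a functional assay on L1210 cells (Mus musculus) for inhibition (a lower number here means a stronger inhibitor, a higher number a weaker inhibitor), and no other compound has been measured there yet. For the measured compounds named here, compound 2, at 5100 nM, cannot be told apart from the only other measured compound. Going by the values given here, the single measured step is a 1.2-fold higher number from compound 1 to compound 2 (0.06 log units; within the scatter), with ethyl in place of vinyl on the chain.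

Compound 3 `NCc1ccc(/C=N/N=C(/N)S)nc1` has no number yet. Its structure differs as follows: aminomethyl in place of propylamino on an aromatic carbon. The measured step changed only the end of a chain, whereas here the whole group is exchanged, so that step is a weak guide. Among the compounds with values here, it is still the only evidence available, and it gives no direction. No step beyond the scatter is therefore expected in this assay, although the uncertainty is wide. The expected change is a 1.2-fold higher number from compound 2 to compound 3 (0.07 log units; within the scatter), as an estimate only. For compound 3 the estimated value is 6000 nM, with an expected range from 2000 nM to 18000 nM.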

Compound 3, half-maximal inhibitory concentration: 2100 nM
Compound 3: middle estimate off by 2.9-fold (0.46 log units), on the high side; measured number inside the range.
By their numbers in this assay, from the lowest: compound 3; then compounds 1 and 2 (each within the scatter of the next).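

In this assay the exchange of the whole group on the aromatic carbon does move the number: putting aminomethyl in place of propylamino gives a 2.4-fold lower number from compound 2 to compound 3 (0.39 log units; beyond the scatter) and putting it in place of allylamino gives a 2.1-fold lower number from compound 1 to compound 3 (0.32 log units; beyond the scatter) so compound 3 is the strongest inhibitor of the three, though both steps are modest. The earlier comparison showed only that altering the end of the chain left the number within the scatter, as a 1.2-fold higher number from compound 1 to compound 2 (0.06 log units; within the scatter) makes plain, whereas this result shows that the same position is not indifferent to what sits there when the group as a whole changes, here from 4 heavy atoms to 2. Nothing measured explains why the number falls.

The single exchange changes the size of the group and its arrangement together, so the compounds shown cannot say which of the two goes with the lower number. Also open, as far as these compounds go, is how a methylamino group, an aminoethyl chain or a hydroxymethyl group on the same aromatic carbon would compare with aminomethyl.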